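Replacing azidomethyl on the shared core: an expected outcome

The source may hold more compounds than are shown below. What is called first, only, known or untested is meant among the compounds shown, and "the series" means these compounds.

Measured in a functional assay on MCF7 cells (Homo sapiens) for antiproliferative activity, read by MTT assay, with a stated time of 48 h (on this read-out higher numbers stand for weaker inhibition and lower numbers for stronger inhibition), so far:
- Compound 1 `COC/C1=C/C[C@](C)(CCC=C(C)C)/C=C/[C@@H](OC(=O)C=C(C)C)[C@](C)(O)/C=C/C1=O` gives 4130 nM
- Compound 2 `CCN(CC)C/C1=C/C[C@](C)(CCC=C(C)C)/C=C/[C@@H](OC(=O)C=C(C)C)[C@](C)(O)/C=C/C1=O` gives 130 nM
- Compound 3 `CC(C)=CCC[C@]1(C)/C=C/[C@@H](OC(=O)C=C(C)C)[C@](C)(O)/C=C/C(=O)/C(CN=[N+]=[N-])=C\C1` gives 4890 nM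

In this assay compound 3 stands at the high, weaker end of these numbers, and it cannot be told apart from compound 1. The data show a 1.2-fold higher number from compound 1 to compound 3 (0.07 log units; within the scatter) and only compound 2 stands clearly apart, with a 38-fold higher number from compound 2 to compound 3 (1.58 log units; beyond the scatter) as the gap.

The next structure is compound 4 `CO/N=C/C1=C/C[C@](C)(CCC=C(C)C)/C=C/[C@@H](OC(=O)C=C(C)C)[C@](C)(O)/C=C/C1=O` and it differs from compound 3 in one place on the shared core: a group of 4 heavy atoms (2 carbon, 1 nitrogen, 1 oxygen; no ring) in place of a group of 4 heavy atoms (1 carbon, 3 nitrogen; no ring), on a double-bonded ring carbon. Azidomethyl leaves, and the entering group has no common name.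

The large steps, a 32-fold lower number from compound 1 to compound 2 (1.50 log units; beyond the scatter) and the gap above, both involve diethylamino, which compound 4 does not carry. The closer guide is the swap of methoxy for azido, which stayed within the scatter. Going by the values given here, no compound with the entering group has been measured, so this remains uncertain. No step beyond the scatter is therefore expected in this assay. The expected result is a 1.2-fold lower number from compound 3 to compound 4 (0.09 log units; within the scatter) and no more. For compound 4 the estimated value is 4000 nM with an expected range from 1500 nM to 11000 nM as its limits.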

Compound 4, half-maximal inhibitory concentration: 2510 nM
Compound 4: the middle estimate sits 1.6-fold (0.20 log units) above what was measured, and the stated range covers the measured number.
By their numbers in this assay, from the lowest: compound 2; then compounds 4, 1 and 3 (each within the scatter of the next).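

The data show a 1.9-fold lower number from compound 3 to compound 4 (0.29 log units; within the scatter) and a 1.6-fold lower number from compound 1 to compound 4 (0.22 log units; within the scatter) in this assay and so add a third group on the double-bonded ring carbon that cannot be told apart from the others without diethylamino. Methoxy, azido and the new group, despite their different atoms, therefore form one level among these compounds, and diethylamino still stands alone at this place, with a 19-fold higher number from compound 2 to compound 4 (1.29 log units; beyond the scatter) as the gap. No measurement is available that explains this difference.

The compounds shown leave open whether the stronger inhibition belongs to diethylamino alone or would also appear with a smaller amine such as dimethylamino. As far as these compounds go, how a carboxylic acid or a longer chain would behave on this ring carbon also remains open.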